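Isopropyl in place of methyl on an amide-type nitrogen

The compounds below may be only part of what the source reports. "The series", "measured", "known", "first", "only" and "open" are said of these compounds alone.

Compound 1 `COc1ccc(-c2nc(/N=C(\N)N(C)C)sc2-c2ccc(OC)cc2)cc1` and compound 2 `CNC(=O)NCc1nc(-c2ccc(OC)cc2)c(-c2ccc(OC)cc2)s1` share a core and differ in one group. In a functional assay with Oryctolagus cuniculus as the target (a lower number here means a stronger inhibitor, a higher number a weaker inhibitor), compound 1 gives 37 nM and compound 2 gives 22 nM. These two values lie within the scatter of each other, so compound 2 stands level with compound 1.

Compound 3 `COc1ccc(-c2nc(CNC(=O)NC(C)C)sc2-c2ccc(OC)cc2)cc1` keeps all of compound 2 except for one small change: isopropyl in place of methyl on an amide-type nitrogen, (isopropyl in place of methyl on an amide-type nitrogen). Within the data shown here, no measured step makes this exact swap, and two compounds give little to go on. The closest evidence is a 1.7-fold lower number from compound 1 to compound 2 (0.23 log units; within the scatter), a swap of a whole group that stayed within the scatter. That step bears on the new change only loosely and gives no direction for it. A shift beyond the scatter is therefore not expected, although the data cannot rule one out.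

The expected change is a 1.4-fold higher number from compound 2 to compound 3 (0.13 log units; within the scatter), an estimate with no firm direction. For compound 3 the estimated value in this assay is 30 nM, with an expected range from 8 nM to 110 nM.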

Compound 3, half-maximal inhibitory concentration: 42 nM
The estimate for compound 3 lay 1.4-fold (0.15 log units) below the measured number, within the range that was stated.
By their numbers in this assay, from the lowest: compounds 2, 1 and 3 (each within the scatter of the next).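

In this assay, isopropyl in place of methyl on the amide-type nitrogen gives a 1.9-fold higher number from compound 2 to compound 3 (0.28 log units; within the scatter) and so moves the number by no more than repeated measurements of the same compound might. Among these compounds, this is the first view of this nitrogen, and it shows that the two small alkyl groups tried here stand level, so neither can be called the better choice. The step that exchanges the whole group on the aromatic carbon gives a 1.1-fold higher number from compound 1 to compound 3 (0.06 log units; within the scatter) and also stays within the scatter, which leaves compounds 1, 2 and 3 on one level in this assay. Nothing available here bears on why the numbers stay so close.

Two small alkyl groups say little about how far this tolerance extends, so a longer chain such as n-butyl or a ring such as cyclohexyl or phenyl on this nitrogen remains an open question. On these data alone, it is also open whether a chain ending in an amine or a carboxylic acid would finally move the number beyond the scatter, and in which direction.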